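The source may report more compounds than this note shows. Statements on the series, on what has been measured and on what is new or still open speak of the compounds shown alone.

Three compounds have numbers in a toxicity assay on L02 cells (Homo sapiens) for cytotoxicity, read by MTT assay, with a stated time of 72 h; on this read-out higher numbers stand for weaker inhibition and lower numbers for stronger inhibition:

Compound 1 `O=C1c2c[n+]([O-])c3ccccc3c2C(=O)c2c1c1ccccc1n2Cc1cn(C[C@@H](O)CO)nn1` gives 490 nM.
Compound 2 `O=C1c2c[n+]([O-])c3ccccc3c2C(=O)c2c1c1ccccc1n2CCCCN1CCNCC1` gives 1380 nM.
Compound 3 `CCCN1CCN(CCCCn2c3c(c4ccccc42)C(=O)c2c[n+]([O-])c4ccccc4c2C3=O)CC1` gives 6830 nM.

Compound 3 stands at the highest number of the three, so it is the weakest inhibitor here: a 4.9-fold higher number from compound 2 to compound 3 (0.69 log units; beyond the scatter), and a 14-fold higher number from compound 1 to compound 3 (1.14 log units; beyond the scatter). Compound 4 `O=C1c2c[n+]([O-])c3ccccc3c2C(=O)c2c1c1ccccc1n2CCCCn1ccnc1` is not yet measured. It differs from compound 3 in one place: 1H-imidazol-1-yl in place of 4-propylpiperazin-1-yl on a saturated chain carbon, four bonds along the chain from an aromatic nitrogen.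

Going by the values given here, two measured steps bear on this. The end of the chain was changed before, and a 14-fold higher number from compound 1 to compound 3 (1.14 log units; beyond the scatter); within that, a 4.9-fold higher number from compound 2 to compound 3 (0.69 log units; beyond the scatter), which removes the propyl that compound 4 also lacks. Compound 4 carries a small aromatic ring at the chain end, as compound 1 does, but without the diol. A lower number than compound 3 is therefore expected, probably landing near compound 2, giving an estimated 6.8-fold lower number from compound 3 to compound 4 (0.83 log units; beyond the scatter). Compound 4 is expected to give about 1000 nM, with a likely range from 300 nM to 3500 nM.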

Compound 4, half-maximal inhibitory concentration: 150 nM
For compound 4 the middle estimate is 6.7-fold (0.82 log units) above the measured one, outside the stated range (below it).
By their numbers in this assay, from the lowest: compound 4; then compound 1; then compound 2; then compound 3.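

In this assay, the group at the chain end alone can move the number a long way: the aromatic 1H-imidazol-1-yl in place of 4-propylpiperazin-1-yl gives (a 46-fold lower number from compound 3 to compound 4 (1.66 log units; beyond the scatter)), and in place of piperazin-1-yl it gives (a 9.2-fold lower number from compound 2 to compound 4 (0.96 log units; beyond the scatter)). The earlier compounds shown here showed only that the piperazine ends sat above compound 1, whereas this change goes past compound 1 (as a 3.3-fold lower number from compound 1 to compound 4 (0.51 log units; beyond the scatter)), so compound 4 is the strongest inhibitor of the four and carries no diol. Nothing available explains why this end group gives the lowest number.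

The imidazole differs from the piperazines in both ring size and aromatic character, and the compounds shown do not separate the two. A morpholin-4-yl end, a 1H-pyrazol-1-yl end or a longer chain carrying the imidazole would each test how far this result extends.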